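Methyl in place of hydrogen on compound 3

The source may report more compounds than this note shows. Statements on the series, on what has been measured and on what is new or still open speak of the compounds shown alone.

In a functional assay on MCF7 cells (Homo sapiens) for inhibition, read by MTT assay, with a stated time of 72 h (on this read-out higher numbers stand for weaker inhibition and lower numbers for stronger inhibition), compound 3 (`COc1cc2c(Oc3ccc(NC(=O)c4nn(-c5ccccc5C)ccc4=O)cc3)ccnc2cc1OCCCCCC(=O)NO`) gives 4360 nM. Compound 1 (`COc1cc2c(Oc3ccc(NC(=O)c4nn(-c5ccccc5C)cc(C)c4=O)cc3)ccnc2cc1OCC(=O)NO`) gives 8780 nM, and compound 2 (`COc1cc2c(Oc3ccc(NC(=O)c4nn(-c5ccccc5C)cc(C)c4=O)cc3)ccnc2cc1OCCCC(=O)NO`) gives 1600 nM. Compound 3 lies within the scatter of compound 1. The gap between compound 3 and compound 2 lies beyond the scatter, with compound 2 at the lower number. Compound 4 (`COc1cc2c(Oc3ccc(NC(=O)c4nn(-c5ccccc5C)cc(C)c4=O)cc3)ccnc2cc1OCCCCCC(=O)NO`) differs from compound 3 by methyl in place of hydrogen on an aromatic carbon. Going by the values given here, no measured pair isolates this methyl. Among the compounds with values here, the one measured step, a 5.5-fold lower number from compound 1 to compound 2 (0.74 log units; beyond the scatter), changes the chain between two compounds that both carry the methyl, so it bears only indirectly. In this assay no step beyond the scatter is therefore expected, and the estimated step is a 1.2-fold lower number from compound 3 to compound 4 (0.10 log units; within the scatter). Compound 4 is estimated at 3500 nM, with an expected range of 1500 nM to 8000 nM.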

Compound 4, half-maximal inhibitory concentration: 1830 nM
Compound 4: the middle estimate sits 1.9-fold (0.28 log units) above what was measured; measured number inside the range.
By their numbers in this assay, from the lowest: compounds 2 and 4 (each within the scatter of the next); then compounds 3 and 1 (each within the scatter of the next).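

In this assay, methyl in place of hydrogen on this aromatic carbon, opposite the ring nitrogen, now has a direct reading on the 4-(hydroxycarbamoyl)butyl chain: a 2.4-fold lower number from compound 3 to compound 4 (0.38 log units; beyond the scatter). With the methyl held, that chain gives a 4.8-fold lower number from compound 1 to compound 4 (0.68 log units; beyond the scatter) against the shortest chain, while a 1.1-fold higher number from compound 2 to compound 4 (0.06 log units; within the scatter) shows no separation from the 2-(hydroxycarbamoyl)ethyl chain. No measured evidence here bears on the cause of the methyl step.

As far as these compounds go, whether the methyl step has the same size on the two shorter chains remains open. So does the outcome with ethyl or chlorine at this carbon, or with a longer chain.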